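Swapping a Butyl Amide for a Cyclopropyl Amide

A few compounds are considered here, and "the series" means these few. Any claim that something is new, unique, unknown or untested is made for them only; others in the source may bear on it.

Compound 1, `CCCCC(=O)N(Cc1ccc(OC)c(O)c1)c1cc(OC)c(OC)c(OC)c1`: 300 nM
Compound 2, `C/C=C/C(=O)N(Cc1ccc(OC)c(Br)c1)c1cc(OC)c(OC)c(OC)c1`: 10500 nM

Both numbers come from a functional assay on KYSE-450 cells (Homo sapiens) for inhibition, read by MTT assay, with a stated time of 48 h; on this read-out lower numbers stand for stronger inhibition and higher numbers for weaker inhibition. Compound 1 holds the lower of the two, and its gap to compound 2 lies beyond the scatter of repeated measurements. Compound 3, `COc1ccc(CN(C(=O)C2CC2)c2cc(OC)c(OC)c(OC)c2)cc1O`, keeps everything in compound 1 except at one place: cyclopropyl in place of butyl on a carbonyl carbon. For the measured compounds named here, no measured pair differs in just this way, so the data give no direct guide to the size of this step. Since the carbonyl, the amide nitrogen and the rest of the molecule stay as in compound 1, the step is expected to be small, a 1.3-fold higher number from compound 1 to compound 3 (0.12 log units; within the scatter), with no clear direction beyond the scatter. For compound 3 the estimated value is 400 nM, within a range from 120 nM to 1500 nM.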

Compound 3, half-maximal inhibitory concentration: 80 nM
The estimate for compound 3 lay 5.0-fold (0.70 log units) above the measured number, and the stated range ends above it.
By their numbers in this assay, from the lowest: compound 3; then compound 1; then compound 2.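

In this assay, cyclopropyl in place of butyl on a carbonyl carbon gives a 3.8-fold lower number from compound 1 to compound 3 (0.57 log units; beyond the scatter), so the group at this place affects the result even when the rest of the molecule stays the same. Within this one pair, the small ring gives the lower number and the open chain the higher. Nothing measured here accounts for the difference.

From the compounds shown here alone, whether a larger ring such as cyclobutyl or cyclohexyl would give a lower or higher number remains open. So does the effect of a shorter chain such as ethyl.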